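Bromo for cyano in a cell tolerance test

A few compounds are considered here, and "the series" means these few. Any claim that something is new, unique, unknown or untested is made for them only; others in the source may bear on it.

Going by the values given here, in an ADME assay on MT4 cells (Homo sapiens) for inhibition, read by MTT assay, with a stated time of 5 days (a higher number here means that more compound is tolerated, a lower number that less compound is tolerated), compound 1 (`Cc1cc(C)c(Oc2cc(Nc3ccc(C#N)cc3)ncc2[N+](=O)[O-])c(C)c1`) gives 69900 nM and compound 2 (`Cc1cc(C#N)cc(C)c1Oc1cc(Nc2ccc(C#N)cc2)ncc1[N+](=O)[O-]`) gives 36100 nM, so compound 2 stands within the scatter of the only other measured value. Compound 3 (`Cc1cc(Br)cc(C)c1Oc1cc(Nc2ccc(C#N)cc2)ncc1[N+](=O)[O-]`) has bromo in place of cyano on an aromatic carbon. Among the compounds with values here, one measured step bears on this change, as it altered the group on that same carbon: a 1.9-fold lower number from compound 1 to compound 2 (0.29 log units; within the scatter). Within the data shown here, with only that small step as a guide, no shift beyond the scatter is expected, in either direction. The expected step is a 1.2-fold higher number from compound 2 to compound 3 (0.10 log units; within the scatter). For compound 3, the estimate is 45000 nM, with a range of 18000 nM to 100000 nM.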

Compound 3, half-maximal cytotoxic concentration: 12300 nM
Compound 3: the middle estimate sits 3.7-fold (0.56 log units) above what was measured; measured number outside the range, below it.
By their numbers in this assay, from the lowest: compound 3; then compounds 2 and 1 (each within the scatter of the next).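

Unlike the swap of methyl for cyano, this change moves the number beyond the scatter in this assay (a 2.9-fold lower number from compound 2 to compound 3 (0.47 log units; beyond the scatter)). Bromo also stands apart from methyl at this carbon (a 5.7-fold lower number from compound 1 to compound 3 (0.75 log units; beyond the scatter)), so the group here can matter for how much compound the cells tolerate, and of these three groups, bromo gives the lowest number. No supporting measurement is available to explain this shift. As far as these compounds go, whether a smaller halogen such as chloro would behave like bromo remains open. So does the effect of an amine or a carboxylic acid on this carbon.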